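Moving a hydroxyl group around one ring

A few compounds are considered here, and "the series" means these few. Any claim that something is new, unique, unknown or untested is made for them only; others in the source may bear on it.

Measured in a functional assay on DU-145 cells (Homo sapiens) for cytotoxicity, read by ELISA, with a stated time of 2 days; on this read-out higher numbers stand for weaker inhibition and lower numbers for stronger inhibition:
compound 1 `Oc1ccccc1-c1cc(-c2ccccc2)nc(-c2ccco2)c1`: 4900 nM
compound 2 `Oc1cccc(-c2cc(-c3ccccc3)nc(-c3ccco3)c2)c1`: 34900 nM
compound 3 `Oc1cccc(-c2cc(-c3ccccc3)nc(-c3ccccn3)c2)c1`: 15500 nM

Of these three, compound 2 has the highest number, 34900 nM, which makes it the weakest inhibitor measured so far. Compound 4 `Oc1ccc(-c2cc(-c3ccccc3)nc(-c3ccco3)c2)cc1` has not yet been measured. It differs from compound 2 in one place, where 4-hydroxyphenyl replaces 3-hydroxyphenyl on an aromatic carbon opposite the ring nitrogen (4-hydroxyphenyl in place of 3-hydroxyphenyl on an aromatic carbon).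

The closest guide is a change of the same kind at the same place, a 7.1-fold higher number from compound 1 to compound 2 (0.85 log units; beyond the scatter), with 3-hydroxyphenyl in place of 2-hydroxyphenyl. It shows that the choice between such groups can shift the number in this assay. The other step, a 2.3-fold lower number from compound 2 to compound 3 (0.35 log units; beyond the scatter), concerns a different place and says less. For the measured compounds named here, no measured compound carries 4-hydroxyphenyl, so the direction remains uncertain. However, compound 2 already sits at the top of the measured numbers, so a modest move downward seems the likelier outcome. The expected change is a 2.3-fold lower number from compound 2 to compound 4 (0.37 log units; beyond the scatter). For compound 4 the estimated value is 15000 nM, with an expected range from 5000 nM to 45000 nM.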

Compound 4, half-maximal inhibitory concentration: 8600 nM
Beside the measured number, compound 4's estimate is 1.7-fold (0.24 log units) above it, and the stated range covers the measured number.
By their numbers in this assay, from the lowest: compounds 1, 4 and 3 (each within the scatter of the next, the first and the last beyond it); then compound 2.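

Moving the hydroxyl from the 3-hydroxyphenyl to the 4-hydroxyphenyl arrangement gives a 4.1-fold lower number from compound 2 to compound 4 (0.61 log units; beyond the scatter), so this position responds to a shift of the hydroxyl in either direction from the 3-hydroxyphenyl group, not only towards the 2-hydroxyphenyl group. The other comparison gives a 1.8-fold higher number from compound 1 to compound 4 (0.24 log units; within the scatter), so the 2-hydroxyphenyl and 4-hydroxyphenyl compounds cannot be told apart here, and among these three arrangements only the 3-hydroxyphenyl group stands apart, with no steady trend as the hydroxyl travels around the ring. No supporting measurement is available to explain this difference between the arrangements.

The compounds shown leave open whether a methoxy group or an amine in the hydroxyl's place would give the same pattern. They also leave open whether the pattern holds when pyridin-2-yl replaces furan-2-yl.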